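Swapping a benzyl for a methyl carbamate: stability expected unchanged

A few compounds are considered here, and "the series" means these few. Any claim that something is new, unique, unknown or untested is made for them only; others in the source may bear on it.

Of the compounds shown here, three sharing one core have been measured in an ADME assay on microsomes from liver (Homo sapiens) for metabolic stability, with a stated time of 10 min; on this read-out higher numbers stand for a more stable compound and lower numbers for a less stable compound. Compound 1 `CC(C)(C)OC(=O)NCCS(=O)(=O)NC(=O)c1ccc(Nc2nc(NC3(c4ccc(Cl)cc4)CC3)nc(OCC(F)(F)F)n2)cc1` gives 92%. Compound 2 `O=C(NS(=O)(=O)CCNC(=O)C1CC1)c1ccc(Nc2nc(NC3(c4ccc(Cl)cc4)CC3)nc(OCC(F)(F)F)n2)cc1` gives 90%. Compound 3 `O=C(NS(=O)(=O)CCNCc1ccccc1)c1ccc(Nc2nc(NC3(c4ccc(Cl)cc4)CC3)nc(OCC(F)(F)F)n2)cc1` gives 99%. The differences among them are small: a number 2 percentage points lower from compound 1 to compound 2 (within the scatter), a number 7 percentage points higher from compound 1 to compound 3 (within the scatter) and a number 9 percentage points higher from compound 2 to compound 3 (within the scatter). Compound 3 thus sits at the top of the three figures, but every step to it lies within the scatter, so the three compounds cannot be told apart on this read-out.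

Compound 4 `COC(=O)NCCS(=O)(=O)NC(=O)c1ccc(Nc2nc(NC3(c4ccc(Cl)cc4)CC3)nc(OCC(F)(F)F)n2)cc1` is the next member. Relative to compound 3 the change is methoxycarbonyl in place of benzyl on an amine nitrogen. The steps from compound 1 to compound 3 and from compound 2 to compound 3 bear on this, since each also replaced a carbonyl-bearing group on that nitrogen with benzyl or the reverse; both were within the scatter. Compound 4 is moreover close to compound 1, whose carbamate differs only in the alkyl group. The expected step is therefore a number 8 percentage points lower from compound 3 to compound 4 (within the scatter), no change beyond the scatter. Compound 4 is estimated at 91%, within a range of 82% to 99%.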

Compound 4, percent of the compound remaining: 90%
For compound 4 the middle estimate is 1 percentage points above the measured one, within the range that was stated.
By their numbers in this assay, from the lowest: compounds 2, 4, 1 and 3 (each within the scatter of the next).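

Methoxycarbonyl in place of benzyl on the amine nitrogen gives a number 9 percentage points lower from compound 3 to compound 4 (within the scatter), so a fourth group at this position still leaves this assay unable to separate the compounds. The two smaller swaps read the same way: methoxy in place of cyclopropyl on a carbonyl carbon gives no change at the digits printed from compound 2 to compound 4 (within the scatter), and methyl in place of tert-butyl on an oxygen next to a carbonyl group gives a number 2 percentage points lower from compound 1 to compound 4 (within the scatter). Carbamates carrying methyl and tert-butyl therefore cannot be told apart on this read-out, and no supporting data offer a reason for this.

As far as these compounds go, it remains open whether a free amine, a carboxylic acid or a longer chain on this nitrogen would also stay within the scatter. Changes elsewhere on the shared core are also untested by these compounds, which vary only in this one region.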